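Removing the bromo from compound 1

This account rests on a few compounds, and the source may have more. Where it says the series, first, only, none or still open, it means among the compounds named here.

Two compounds have been measured so far in a functional assay on NCI/ADR-RES cells (Homo sapiens) for inhibition, read by spectrophotometry and sulforhodamine B assay, with a stated time of 48 h (a higher number here means a weaker inhibitor of growth, a lower number a stronger inhibitor of growth), with these results
- compound 1 `Cc1ccc(N2C(=O)CS/C2=N/N=C/c2c[nH]c3ccc(Br)cc23)cc1` gives 64600 nM
- compound 2 `O=C1CS/C(=N/N=C/c2c[nH]c3ccccc23)N1c1cccc2ccccc12` gives 38600 nM

Compound 1 holds the higher of just two numbers, but compound 2 lies within the usual scatter of it, so the pair cannot be separated in this assay on these data. Among the compounds with values here, the two compounds differ in more than one place, and no measured step isolates a single change.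

Compound 3 `Cc1ccc(N2C(=O)CS/C2=N/N=C/c2c[nH]c3ccccc23)cc1` has not yet been measured. It keeps the core of compound 1 and has hydrogen in place of bromo on an aromatic carbon. Within the data shown here, no measured pair gives the size of this change. Compound 2 also carries no bromo and gives 38600 nM, which is within the scatter of compound 1. A step beyond the scatter is therefore not expected in this assay, and no direction is favoured. The estimated change is a 1.3-fold lower number from compound 1 to compound 3 (0.13 log units; within the scatter). For compound 3 the expected value is 48000 nM, with an estimated range of 22000 nM to 100000 nM.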

Compound 3, concentration for 50% growth inhibition: > 100000 nM
Compound 3 was reported as a limit; the forecaster's own chance of this, stated with the estimate: 15%; middle value at least 2.0-fold (0.31 log units) away from the limit.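

In this assay compound 3 is reported as a limit, > 100000 nM, not as a number. This is the one step shown that isolates the bromo on this aromatic carbon, where the earlier compounds differed in more than one place: hydrogen in place of bromo gives an at least 1.5-fold higher number from compound 1 to compound 3 (0.18 log units; that floor lies within the scatter). The step points towards a weaker inhibitor of growth on losing the bromo, but its floor does not clear the scatter, and it has no upper end, so its size cannot be stated: the limit of > 100000 nM in this assay, at which 1 of the 3 values shown sits.

The compounds shown leave open how far the step really runs, and whether bromine itself matters at this position or whether another group on the same aromatic carbon, such as chloro, fluoro, methoxy or a nitrile, would give a value like that of compound 1. They also leave open whether a bromo on the same aromatic carbon of compound 2 would shift its value in this assay, which would show whether this step holds with a different group on the core.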